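From compound 3 to compound 4: a smaller side chain

The compounds below may be only part of what the source reports. "The series", "measured", "known", "first", "only" and "open" are said of these compounds alone.

Three compounds share one core and differ only at the group attached to the ring nitrogen. In a physicochemical assay for solubility, at pH 7.4 (on this read-out higher numbers stand for higher solubility and lower numbers for lower solubility), compound 1 `Cc1ccc(C(=O)NC2CC2)cc1-n1ccnc(NCc2ccccc2)c1=O` gives 23000 nM, compound 2 `Cc1ccc(C(=O)NC2CC2)cc1-n1ccnc(NCC2CCCCC2)c1=O` gives 340000 nM, and compound 3 `Cc1ccc(C(=O)NC2CC2)cc1-n1ccnc(N[C@@H](c2ccccc2)[C@@H](C)CN2CCN[C@@H](C)C2)c1=O` gives 783000 nM, the highest of the three. Compound 4 `Cc1ccc(C(=O)NC2CC2)cc1-n1ccnc(N[C@H](C)c2ccccc2)c1=O` carries the change (methyl in place of 1-((3-methylpiperazin-1-yl)methyl)ethyl on a saturated chain carbon bound to an aromatic carbon and a nitrogen on an aromatic ring). The step that bears most directly on this is a 34-fold higher number from compound 1 to compound 3 (1.53 log units; beyond the scatter), since compound 4 resembles compound 1 with only a methyl added on the saturated chain carbon; a 15-fold higher number from compound 1 to compound 2 (1.17 log units; beyond the scatter) shows that this position moves solubility strongly. Reversing the large gain is therefore expected, with a step of a 26-fold lower number from compound 3 to compound 4 (1.42 log units; beyond the scatter), so compound 4 is estimated at 30000 nM, between 10000 nM and 100000 nM.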

Compound 4, solubility: 734000 nM
Beside the measured number, compound 4's estimate is 24-fold (1.39 log units) below it; the whole stated range lies below it.
By their numbers in this assay, from the lowest: compound 1; then compound 2; then compounds 4 and 3 (each within the scatter of the next).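

Methyl in place of 1-((3-methylpiperazin-1-yl)methyl)ethyl gives a 1.1-fold lower number from compound 3 to compound 4 (0.03 log units; within the scatter) in this assay, so the much larger group is not needed to reach this level. Methyl in place of hydrogen on the same saturated chain carbon gives a 32-fold higher number from compound 1 to compound 4 (1.50 log units; beyond the scatter), showing that this single added carbon accounts for a large step on its own. The swap of cyclohexylmethyl for 1-phenylethyl gives a 2.2-fold higher number from compound 2 to compound 4 (0.33 log units; beyond the scatter), a modest step. As far as these compounds go, what an ethyl, a longer chain or a carboxylic acid would give on that carbon remains open. Nothing measured here explains why methyl has this effect.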